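The source may report more compounds than this note shows. Statements on the series, on what has been measured and on what is new or still open speak of the compounds shown alone.

Compound 3 `COc1ccc2nc(C)cc(OCC(=O)Nc3ccccn3)c2c1` sits at the bottom of the three measured numbers in a physicochemical assay for solubility, in phosphate buffer, measured as kinetic solubility, with a stated time of 1 h, at pH 7.4 (on this read-out higher numbers stand for higher solubility and lower numbers for lower solubility), where compound 3 gives 29000 nM. Its two neighbours are compound 1 `COc1ccc2nc(C)cc(OCC(=O)NCc3cc(C)cc(C)c3)c2c1`, which in this assay gives 92000 nM, and compound 2 `COc1ccc(NC(=O)COc2cc(C)nc3ccc(OC)cc23)cc1`, which gives 108000 nM. The step of a 1.2-fold higher number from compound 1 to compound 2 (0.07 log units; within the scatter) stays within the scatter, while a 3.2-fold lower number from compound 1 to compound 3 (0.50 log units; beyond the scatter) and a 3.7-fold lower number from compound 2 to compound 3 (0.57 log units; beyond the scatter) both count as modest but real.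

Compound 4 `COc1ccc2nc(C)cc(OCC(=O)Nc3cc(C)nc(C)n3)c2c1` differs from compound 3 in one place: 2,6-dimethylpyrimidin-4-yl in place of pyridin-2-yl on an amide-type nitrogen. The measured steps that bear on this change are the two leading into compound 3, a 3.2-fold lower number from compound 1 to compound 3 (0.50 log units; beyond the scatter) and a 3.7-fold lower number from compound 2 to compound 3 (0.57 log units; beyond the scatter), each of which swaps a carbon-based ring on the amide-type nitrogen for pyridin-2-yl. For the measured compounds named here, none of them exchanges one nitrogen-containing ring for another, so the present change has no direct precedent among the measured compounds. The step of a 1.2-fold lower number from compound 3 to compound 4 (0.06 log units; within the scatter) is therefore expected to stay within the scatter. Compound 4 is estimated at 25000 nM in this assay, in a range from 8000 nM to 80000 nM.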

Compound 4, solubility: 5000 nM
Compound 4: the middle estimate sits 5.0-fold (0.70 log units) above what was measured, and the stated range ends above it.
By their numbers in this assay, from the lowest: compound 4; then compound 3; then compounds 1 and 2 (each within the scatter of the next).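

For the compounds shown here, replacing pyridin-2-yl with 2,6-dimethylpyrimidin-4-yl on the amide-type nitrogen gives, in this assay, a 5.8-fold lower number from compound 3 to compound 4 (0.76 log units; beyond the scatter), which shows that this position separates one nitrogen-containing ring from another, a contrast the earlier compounds did not cover. Going by these compounds alone, the same group also gives a 22-fold lower number from compound 2 to compound 4 (1.33 log units; beyond the scatter) and an 18-fold lower number from compound 1 to compound 4 (1.26 log units; beyond the scatter), both large steps, whereas the earlier steps at this place were modest or within the scatter. Nothing available gives a reason for the drop.

The entering group differs from pyridin-2-yl in both its second ring nitrogen and its two methyl groups, and the compounds shown do not separate these two features. They also leave open how a ring carrying an amine or a carboxylic acid would read at this position.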